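Notes on the aryl-imidazoline series: compound 2 to compound 4

This account rests on a few compounds, and the source may have more. Where it says the series, first, only, none or still open, it means among the compounds named here.

Compound 2 `Cc1nc(-c2ccccc2NCC2=NCCN2)cs1` and compound 3 `Cc1ccc(-c2ccccc2NCC2=NCCN2)o1` carry five-membered aromatic groups on the shared core; compound 1 `Cc1ncc(-c2ccccc2NCC2=NCCN2)o1` carries 2-methyl-1,3-oxazol-5-yl in the same place. In a functional assay for activation of Alpha-1B adrenergic receptor (Homo sapiens), read by calcium flux (on this read-out higher numbers stand for an effect only at larger amounts of compound and lower numbers for an effect already at smaller amounts), compound 2 gives 69.2 nM, the highest of the two numbers shown. Compound 3 gives 46.8 nM in this assay, and the step between them is a 1.5-fold lower number from compound 2 to compound 3 (0.17 log units; within the scatter). Compound 1 reaches only a limit of this assay, < 5020 nM (the limit of < 5020 nM in this assay, at which 1 of the 3 values shown sits). The steps a step that the limit leaves unreadable from compound 1 to compound 2 and a step that the limit leaves unreadable from compound 1 to compound 3 carry no readable size.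

Compound 4 `CC/C(=N\OC)c1ccccc1NCC1=NCCN1` is to be measured in this assay. It differs from compound 2 as follows: a group of 6 heavy atoms (4 carbon, 1 nitrogen, 1 oxygen; no ring) in place of a group of 6 heavy atoms (4 carbon, 1 nitrogen, 1 sulfur; one five-membered aromatic ring with 2 hetero atoms), on an aromatic carbon. For the measured compounds named here, no measured step exchanges a ring for an open chain; the only readable step, a 1.5-fold lower number from compound 2 to compound 3 (0.17 log units; within the scatter), swaps one five-membered aromatic group for another and stays within the scatter. No direction beyond the scatter is therefore expected, but the change is of a different kind from any measured one, so the range is set wide. Compound 4 is estimated at 80 nM, between 20 nM and 400 nM, which means an expected step of a 1.2-fold higher number from compound 2 to compound 4 (0.06 log units; within the scatter).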

Compound 4, half-maximal effective concentration: < 100000 nM
Compound 4 was reported as a limit; the forecaster's own chance of this, stated with the estimate: 10%; the middle value lies beyond the limit too.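

For the compounds shown here, compound 4 gives only a limit (< 100000 nM), and no step to it from compound 1, compound 2 or compound 3 can be read. The compounds shown leave open how far an open chain in place of a five-membered aromatic ring moves the number in this assay on this core.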